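This account rests on a few compounds, and the source may have more. Where it says the series, first, only, none or still open, it means among the compounds named here.

Measured compounds in the series:
- compound 1, `CNc1nc(OC)nc2c1ncn2C1O[C@H](CO)[C@H](O[C@@H]2OC(CO)[C@H](OP(=O)(O)O)C(OP(=O)(O)O)[C@@H]2O)[C@@H]1OP(=O)(O)O`: 34%
- compound 2, `COc1ncnc2c1ncn2C1O[C@H](CO)[C@H](O[C@@H]2OC(CO)[C@H](OP(=O)(O)O)C(OP(=O)(O)O)[C@@H]2O)[C@@H]1OP(=O)(O)O`: 34%

Compound 1 and compound 2 were both run in a functional assay on the whole organism with Rattus norvegicus as the target; on this read-out higher numbers stand for larger maximal responses and lower numbers for smaller maximal responses. On that read-out compound 2 stands level with compound 1 at the digits shown; its nearest neighbour in value is compound 1, and the two numbers differ by nothing beyond the usual scatter. Within the data shown here, no single-site step between measured compounds is available, so the two values say only that both compounds reach the same maximal response.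

Compound 3, `O=P(O)(O)OC1[C@@H](OP(=O)(O)O)C(CO)O[C@@H](O[C@@H]2[C@H](OP(=O)(O)O)C(n3cnc4c(NC5CCCCC5)ncnc43)O[C@@H]2CO)[C@H]1O`, is the next compound for this assay. Against compound 2 the change is cyclohexylamino in place of methoxy on an aromatic carbon. Among the measured compounds shown here, since no step between measured compounds is known, the size of the step from compound 2 to compound 3 can only be judged from the change itself: a larger group with a ring and a hydrogen-bond donor replaces a small one. A moderate shift is expected, more likely upward than downward, but a result within the scatter remains possible. For compound 3 in this assay the estimated value is 42% with a range of 18% to 70%, which corresponds to an expected step of a number 8 percentage points higher from compound 2 to compound 3 (within the scatter).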

Compound 3, largest response reached (reported as maximal response), in percent of the reference or control that the assay uses: 45%
The estimate for compound 3 lay 3 percentage points below the measured number; measured number inside the range.
By their numbers in this assay, from the lowest: compounds 1 and 2 (each within the scatter of the next); then compound 3.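

In this assay, among these compounds, exchanging methoxy for cyclohexylamino on an aromatic carbon of the six-membered aromatic ring with 2 nitrogen gives the only step that can be read so far, a number 11 percentage points higher from compound 2 to compound 3 (beyond the scatter), showing that the maximal response changes with the group at this position. The step is modest, but it shows that this position accepts a much larger group carrying a six-membered non-aromatic ring of carbon only and a hydrogen-bond donor without any loss of maximal response. No measurement available here bears on why the response changes.

The single exchange alters size, ring and hydrogen-bond donor together, so the compounds shown cannot assign the step to any one of these features. A plain amine, a cyclopentylamino group or an open-chain hexylamino group on the same carbon would help separate them and would test whether the maximal response follows ring size or the presence of a ring at all, while a phenylamino group would compare an aromatic ring with the carbon-only ring.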